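The source may hold more compounds than are shown below. What is called first, only, known or untested is meant among the compounds shown, and "the series" means these compounds.

Three compounds of this series have been run in a functional assay on DU-145 cells (Homo sapiens) for inhibition, read by trypan blue exclusion, with a stated time of 96 h; a higher number here means a weaker inhibitor of growth, a lower number a stronger inhibitor of growth. Compound 1 `Cc1ccsc1/C=C(/SCc1ccc(Cl)cc1)C(=O)c1ccc(Cl)cc1` gives 50000 nM, compound 2 `COc1ccccc1/C=C(/SCc1ccc(Cl)cc1)C(=O)c1ccc(Cl)cc1` gives 1000 nM, and compound 3 `Cc1ccc(/C=C(/SCc2ccc(Cl)cc2)C(=O)c2ccc(Cl)cc2)s1` gives 50000 nM. Among the measured compounds shown here, all three variations so far sit on the double-bonded chain carbon bound to a double-bonded chain carbon: a 50-fold lower number from compound 1 to compound 2 (1.70 log units; beyond the scatter), no change at the digits printed from compound 1 to compound 3 (within the scatter), and a 50-fold higher number from compound 2 to compound 3 (1.70 log units; beyond the scatter). Compound 2 therefore holds the lowest of the three numbers, and its nearest neighbour, compound 1, stands well beyond the scatter from it.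

Compound 4 `COc1ccccc1/C=C(/Sc1ccc(C)cc1)C(=O)c1ccc(Cl)cc1` keeps the 2-methoxyphenyl of compound 2 and alters only the other side: 4-methylphenyl in place of 4-chlorobenzyl on a sulfur, on a sulfur whose other neighbours are a double-bonded chain carbon. For the measured compounds named here, none of the measured steps touches this sulfur substituent; the three steps in hand concern only the aryl group on the chain carbon, so they give no direct precedent for the size or direction of this change. The 4-chlorobenzyl is shared by compounds 1, 2 and 3, so nothing shows whether it is needed for the low number of compound 2.

Going by the values given here, with no bearing step, the working expectation for compound 4 is a number near that of compound 2, allowing a step of a 3.0-fold higher number from compound 2 to compound 4 (0.48 log units; beyond the scatter) in either direction; the estimate is 3000 nM, within 600 nM to 15000 nM.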

Compound 4, concentration for 50% growth inhibition: 25000 nM
Beside the measured number, compound 4's estimate is 8.3-fold (0.92 log units) below it; measured number outside the range, above it.
By their numbers in this assay, from the lowest: compound 2; then compounds 4, 1 and 3 (each within the scatter of the next).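

In this assay, the sulfur substituent proves to be a position that responds strongly: with the 2-methoxyphenyl held fixed, 4-methylphenyl in place of 4-chlorobenzyl gives a 25-fold higher number from compound 2 to compound 4 (1.40 log units; beyond the scatter) and removes most of what set compound 2 apart. The low number of compound 2 therefore does not rest on the 2-methoxyphenyl alone, but holds only with the 4-chlorobenzyl on the sulfur, at least among the compounds in hand. No measurement in hand offers an explanation for this step.

The step changes two things at once, a benzyl becoming a phenyl and a chlorine becoming a methyl, so the compounds shown cannot say which of the two carries the loss; 4-chlorophenyl or 4-methylbenzyl on the sulfur would separate them. Also open, from the compounds shown here alone, are how a longer chain between the sulfur and the ring would read, whether an amine or a carboxylic acid on that ring would be tolerated, and whether the 4-chlorobenzyl would have the same bearing with the methylthiophene groups on the chain carbon.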